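Sulfonamide nitrogen substituent and oral bioavailability

The compounds below may be only part of what the source reports. "The series", "measured", "known", "first", "only" and "open" are said of these compounds alone.

Compound 3 `O=S(=O)(Nc1ccc(Cl)cc1)c1ccc2nc(-c3ccccc3)c(-c3ccccc3)nc2c1` in an ADME assay on the whole organism for pharmacokinetics, with Homo sapiens as the target (on this read-out lower numbers stand for lower oral bioavailability and higher numbers for higher oral bioavailability), gives 100%, level with compound 1 `O=S(=O)(Nc1cccc2ccccc12)c1ccc2nc(-c3ccccc3)c(-c3ccccc3)nc2c1`, which gives 100%; together these are the highest of the three numbers. Compound 2 `CC(=O)c1cccc(NS(=O)(=O)c2ccc3nc(-c4ccccc4)c(-c4ccccc4)nc3c2)c1` gives 96.9%. The three steps among them, a number 3.1 percentage points lower from compound 1 to compound 2 (within the scatter), no change at the digits printed from compound 1 to compound 3 (within the scatter) and a number 3.1 percentage points higher from compound 2 to compound 3 (within the scatter), all fall within the scatter, and each swaps one aryl group for another on the sulfonamide nitrogen. Compound 4 `O=C(NS(=O)(=O)c1ccc2nc(-c3ccccc3)c(-c3ccccc3)nc2c1)c1ccccc1` differs from compound 3 by benzoyl in place of 4-chlorophenyl on a sulfonamide nitrogen. Among the compounds with values here, no measured step replaces an aryl group with a benzoyl group on that nitrogen, so the measured steps bear on this change only loosely. A modest downward step is therefore expected, a number 20 percentage points lower from compound 3 to compound 4 (beyond the scatter), with a wide range. Compound 4 is estimated at 80%, between 45% and 100%.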

Compound 4, oral bioavailability: 100%
Beside the measured number, compound 4's estimate is 20 percentage points below it; low and high end bracket the measured number.
By their numbers in this assay, from the lowest: compounds 2, 1, 3 and 4 (each within the scatter of the next).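

With benzoyl on the sulfonamide nitrogen, this assay shows no change at the digits printed from compound 3 to compound 4 (within the scatter) and no change at the digits printed from compound 1 to compound 4 (within the scatter) and a number 3.1 percentage points higher from compound 2 to compound 4 (within the scatter). Within the data shown here, the position therefore accepts a carbonyl attached directly to that nitrogen, not only the aryl groups of the earlier compounds, with no difference readable beyond the scatter. Nothing at hand offers an explanation for this result.

Still open, as far as these compounds go, is whether any group on this nitrogen moves the read-out beyond the scatter. A longer alkyl chain, an amine or a carboxylic acid there would test this.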